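A few compounds are considered here, and "the series" means these few. Any claim that something is new, unique, unknown or untested is made for them only; others in the source may bear on it.

Measured in an ADME assay on a cell-free system (plasma, Homo sapiens); on this read-out higher numbers stand for a larger free fraction and lower numbers for a smaller free fraction:
- compound 1 `CCNC(=O)Nc1nc2cc(-c3cccnc3)c(=O)n(C(C)C)c2s1`: 0.21
- compound 2 `C=CCNC(=O)Nc1nc2cc(-c3cccnc3)c(=O)n(CCC(C)C)c2s1`: 0.03
- compound 3 `CCNC(=O)Nc1nc2cc(-c3cccnc3)c(=O)n(CCC(C)C)c2s1`: 0.06

Compound 3 lies close to compound 2, with a 2.0-fold higher number from compound 2 to compound 3 (0.30 log units; within the scatter), but clearly apart from compound 1, with a 3.5-fold lower number from compound 1 to compound 3 (0.54 log units; beyond the scatter). The next compound, compound 4 `CCNC(=O)Nc1nc2cc(-c3cccnc3)c(=O)n(C(C)C(N)=O)c2s1`, carries 1-carbamoylethyl in place of isopentyl on an aromatic nitrogen. Going by the values given here, only the step between compound 1 and compound 3 changes that same group, and it suggests that losing isopentyl raises the number. The step from compound 2 changes another part of the molecule. Among the compounds with values here, no measured compound carries 1-carbamoylethyl, so the expectation stays loose. A rise of similar size is expected in this assay, estimated as a 4.0-fold higher number from compound 3 to compound 4 (0.60 log units; beyond the scatter). The estimated value for compound 4 is 0.24, within a range from 0.11 to 0.5.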

Compound 4, unbound fraction: 0.25
Compound 4: the middle estimate sits 1.0-fold (0.02 log units) below what was measured; the measured number falls inside the stated range.
By their numbers in this assay, from the lowest: compounds 2 and 3 (each within the scatter of the next); then compounds 1 and 4 (each within the scatter of the next).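

Placing 1-carbamoylethyl on the aromatic nitrogen instead of isopentyl, with the same count of heavy atoms but a hydrogen-bond donor and acceptor added, gives a 4.2-fold higher number from compound 3 to compound 4 (0.62 log units; beyond the scatter) in this assay. Carbamoyl in place of methyl on the short branched group gives a 1.2-fold higher number from compound 1 to compound 4 (0.08 log units; within the scatter), so at this position the carbamoyl makes no readable difference to the free fraction compared with isopropyl. Nothing available explains these numbers. Open, as far as these compounds go, is how a carboxylic acid or an amine in place of the carbamoyl would read in this assay. Also open, from the compounds shown here alone, is whether a longer chain carrying the carbamoyl would give a number nearer to that of compound 3 or compound 4.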